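This account rests on a few compounds, and the source may have more. Where it says the series, first, only, none or still open, it means among the compounds named here.

Working notes on the series. For the measured compounds named here, in a physicochemical assay for lipophilicity, read by HPLC, at pH 7.5 (on this read-out lower numbers stand for lower lipophilicity and higher numbers for higher lipophilicity), compound 3 `CC[C@@H](Nc1c(C#N)c(-c2ccc(-c3ccccc3COC)cc2)nc2cnccc12)C(N)=O` stands second highest of the three numbers so far: compound 3 gives 2.6, while compound 1 `CC[C@@H](Nc1c(C#N)c(-c2ccc(-c3ncccc3C)cc2)nc2cnccc12)C(N)=O` gives 2 and compound 2 `CC[C@@H](Nc1c(C#N)c(-c2ccc(-c3ccccc3N(C)C)cc2)nc2cnccc12)C(N)=O` gives 3.2. The measured steps are a number 1.20 log units higher from compound 1 to compound 2 (beyond the scatter), a number 0.60 log units higher from compound 1 to compound 3 (beyond the scatter) and a number 0.60 log units lower from compound 2 to compound 3 (beyond the scatter). Compound 4 `CC[C@@H](Nc1c(C#N)c(-c2ccc(-c3ccccc3C(C)C)cc2)nc2cnccc12)C(N)=O` is not yet measured and differs from compound 3 as follows: isopropyl in place of methoxymethyl on an aromatic carbon. Going by the values given here, no measured step exchanges methoxymethyl for isopropyl, so the expectation rests on the general run of the series, where every change at this position has moved the read-out beyond the scatter. An upward step is expected, roughly a number 0.90 log units higher from compound 3 to compound 4 (beyond the scatter). Compound 4 is therefore estimated at 3.5, with a range from 3 to 4.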

Compound 4, distribution coefficient: 3.5
Beside the measured number, compound 4's estimate shows no gap at the digits printed, within the range that was stated.
By their numbers in this assay, from the lowest: compound 1; then compound 3; then compounds 2 and 4 (each within the scatter of the next).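

Methoxymethyl and isopropyl both hold 3 heavy atoms, yet their exchange at this position, which removes the hydrogen-bond acceptor, still moves the read-out in this assay (a number 0.90 log units higher from compound 3 to compound 4 (beyond the scatter)). Isopropyl in place of dimethylamino leaves the two compounds unseparated (a number 0.30 log units higher from compound 2 to compound 4 (within the scatter)), while 2-isopropylphenyl in place of 3-methylpyridin-2-yl gives the largest step listed for the series (a number 1.50 log units higher from compound 1 to compound 4 (beyond the scatter)). No measurement on hand explains these steps.

Open, going by these compounds, is how a carboxylic acid or a primary amine would read at this position. Also open, on these data alone, is whether a longer alkyl chain would read apart from isopropyl.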